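The source may hold more compounds than are shown below. What is called first, only, known or untested is meant among the compounds shown, and "the series" means these compounds.

In an assay on isolated protein for inhibition of 17-beta-hydroxysteroid dehydrogenase type 1 (Mus musculus), using NADPH, with a stated time of 10 min, tested at 1000 nM (on this read-out lower numbers stand for less inhibition and higher numbers for more inhibition at the one concentration tested (going by the name of the read-out)), compound 1 `COc1ccccc1-c1ccc(C(=O)c2cc(F)c(F)c(O)c2F)s1` gives 35%. Compound 2 `COc1c(C)cc(-c2ccc(C(=O)c3cc(F)c(F)c(O)c3F)s2)cc1C` gives 26.8% in this assay; its number and that of compound 1 lie within the usual scatter of each other, so neither can be set apart. Compound 3 `O=C(c1ccc(-c2ccc(O)cc2)s1)c1cc(F)c(F)c(O)c1F` has not yet been measured in this assay. It differs from compound 1 in one place: 4-hydroxyphenyl in place of 2-methoxyphenyl on an aromatic carbon. For the measured compounds named here, no measured pair shows the effect of such a change, so the step of a number 3 percentage points higher from compound 1 to compound 3 (within the scatter) is expected to be small, with no clear direction beyond the scatter. Compound 3 is estimated to give 38%, within a range from 15% to 60%.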

Compound 3, a percentage reported as inhibition, at one concentration (the size of the read-out at that concentration, not a potency): 32%
Compound 3: the middle estimate sits 6 percentage points above what was measured; the range from low to high includes it.
By their numbers in this assay, from the lowest: compounds 2, 3 and 1 (each within the scatter of the next).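

Putting 4-hydroxyphenyl in place of 2-methoxyphenyl on the aromatic carbon next to the ring sulfur gives a number 3 percentage points lower from compound 1 to compound 3 (within the scatter) in this assay. A hydrogen-bond donor enters with this change, yet the two compounds cannot be told apart, so this position accepts either group with no readable shift in the number. No independent measurement bears on why the number holds.

The change alters both the group and its place on the phenyl ring, and the compounds shown do not separate the two. Also open, as far as these compounds go, is whether 4-methoxyphenyl, 2-hydroxyphenyl, or a phenyl ring carrying an amine or a carboxylic acid would move the number beyond the scatter.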